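The source may hold more compounds than are shown below. What is called first, only, known or untested is meant among the compounds shown, and "the series" means these compounds.

Values in a functional assay on NCI-H460 cells (Homo sapiens) for antiproliferative activity, read by sulforhodamine B assay, with a stated time of 48 h (a lower number here means a stronger inhibitor, a higher number a weaker inhibitor), so far:
- compound 1 `O=C(CCCCCCN1C(=O)/C(=N\O)c2ccccc21)NO` gives 890 nM
- compound 2 `CO/N=C1/C(=O)N(CCCCCCC(=O)NO)c2ccccc21` gives 750 nM
- compound 3 `CO/N=C1/C(=O)N(CCCCCCC(=O)NO)c2ccc(F)cc21` gives 970 nM

Compound 3 at 970 nM lies within the scatter of both compound 1 and compound 2, so these three values do not separate. The next compound is compound 4 `CO/N=C1/C(=O)N(CCCCCCC(=O)NO)c2ccc(Cl)cc21` with chloro in place of fluoro on an aromatic carbon of the shared core. For the measured compounds named here, only one measured step bears on this place, namely a 1.3-fold higher number from compound 2 to compound 3 (0.11 log units; within the scatter) for fluoro in place of hydrogen on an aromatic carbon, and it stays within the scatter. Going by the values given here, no chloro compound has been measured yet, so the swap itself has no direct precedent. In this assay no step beyond the scatter is therefore expected, and the estimated move is a 1.1-fold lower number from compound 3 to compound 4 (0.03 log units; within the scatter) with no firm direction. For compound 4 the expected value is 900 nM with an estimated range from 480 nM to 1700 nM on present data.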

Compound 4, half-maximal inhibitory concentration: 760 nM
For compound 4 the middle estimate is 1.2-fold (0.07 log units) above the measured one; measured number inside the range.
By their numbers in this assay, from the lowest: compounds 2, 4, 1 and 3 (each within the scatter of the next).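

In this assay, for the compounds shown here, the first chloro compound at this aromatic carbon of the shared core gives a 1.3-fold lower number from compound 3 to compound 4 (0.11 log units; within the scatter) against fluoro and a 1.0-fold higher number from compound 2 to compound 4 (0.01 log units; within the scatter) against hydrogen. Taken with the earlier fluoro step, hydrogen, fluoro and chloro at this place do not separate, and neither halogen gives a step beyond the scatter, so the position shows no readable preference among these three. No measured evidence is available to account for these values.

The compounds shown leave open how a methoxy group, an amine or a carboxylic acid at this aromatic carbon would read. Also open, on these data alone, is how a shorter or longer chain in place of the shared one would read, and whether any such change would produce a step beyond the scatter.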